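A Longer Chain on the Carbonyl of Compound 1

The source may report more compounds than this note shows. Statements on the series, on what has been measured and on what is new or still open speak of the compounds shown alone.

Three measured compounds share a core in which two aromatic rings are joined through a four-carbon ether linker, one ring carrying a carboxylic acid and the other a ketone. Compound 1 `COc1cc(C(=O)O)ccc1OCCCCOc1ccc(C(=O)C(C)C)c(O)c1C` gives 25.6% in an assay on HEK293 cells for positive allosteric modulation of metabotropic glutamate receptor 3 (Rattus norvegicus), read by thallium flux, with a stated time of 2.5 min; a higher number here means a larger maximal response, a lower number a smaller maximal response. Compound 2 `CCCC(=O)c1ccc(OCCCCOc2cccc(C(=O)O)c2C)c(C)c1O` reaches 53% in this assay, and compound 3 `Cc1c(OCCCCOc2ccc(C(=O)O)cc2Cl)ccc(C(=O)CC2CCCC2)c1O` reaches 27.4%. Compound 1 has the lowest of the three numbers: its gap to compound 3 lies within the usual scatter of repeated measurements, while compound 2 stands beyond the scatter above it. No pair among these three differs in only one place, so no single structural change can be read off from them.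

Compound 4 `COc1cc(C(=O)O)ccc1OCCCCOc1ccc(C(=O)CC(C)C)c(O)c1C` differs from compound 1 in one place: isobutyl in place of isopropyl on a carbonyl carbon. The change replaces the isopropyl group on the carbonyl carbon with an isobutyl group. Among the compounds with values here, nothing among the measured compounds isolates a change of this kind; compound 2 and compound 3 carry other chains on their carbonyl carbons, but each also differs from compound 1 elsewhere. The step of a number 6.4 percentage points higher from compound 1 to compound 4 (within the scatter) is therefore expected to be small, not beyond the scatter in either direction. Compound 4 is estimated to give 32% in this assay, with a likely range from 18% to 50%.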

Compound 4, largest response reached (reported as percent of maximum), in percent of the reference or control that the assay uses: 73.9%
Compound 4: the middle estimate sits 41.9 percentage points below what was measured; the measured number lies above the stated range.
By their numbers in this assay, from the lowest: compounds 1 and 3 (each within the scatter of the next); then compound 2; then compound 4.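

In this assay, a change of only one carbon, from isopropyl to isobutyl on a carbonyl carbon whose other neighbour is an aromatic carbon, gives a number 48.3 percentage points higher from compound 1 to compound 4 (beyond the scatter). Within the data shown here, this shows that the maximal response can depend strongly on which small chain sits at this position, even though the step looked likely to be minor from the earlier compounds, none of which isolated this position. Neither group has a ring, a hydrogen-bond donor, a hydrogen-bond acceptor or a net charge, so the large step comes without a change in any of these counts, and no measurement shown here explains it.

From the compounds shown here alone, it remains open whether a longer chain such as pentyl, or a cyclohexyl ring, on this carbonyl carbon would raise the response further, lower it or leave it unchanged. Going by these compounds, it is also open whether the same swap from isopropyl to isobutyl would produce a similar step on a core with different substituents on the acid-bearing ring, such as the chlorine of compound 3.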